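A few compounds are considered here, and "the series" means these few. Any claim that something is new, unique, unknown or untested is made for them only; others in the source may bear on it.

Measured compounds in a functional assay on MV4-11 cells (Homo sapiens) for antiproliferative activity, with a stated time of 6 days, tested at 1.56 uM; a higher number here means a stronger effect of the compound at the concentration tested, a lower number a weaker effect:
Compound 1, `CNC(=O)N1CCCc2ccc(NC(=O)c3ccc(-c4ccccc4)cc3)cc21`, gives 19.7%.
Compound 2, `CNC(=O)N1CCCc2ccc(NC(=O)c3cccc(-c4cc[nH]n4)c3)cc21`, gives 27.3%.
Compound 3, `CNC(=O)N1CCCc2ccc(NC(=O)c3cccc(-c4cnn(S(C)(=O)=O)c4)c3)cc21`, gives 1.6%.

All three share one core and were tested in this assay. Compound 1 stands second highest of the three numbers: compound 2 lies within the scatter of it, while compound 3 lies beyond the scatter below it. For the measured compounds named here, the one step between compounds that differ in a single place is a number 25.7 percentage points lower from compound 2 to compound 3 (beyond the scatter), with 1-(methylsulfonyl)-1H-pyrazol-4-yl in place of 1H-pyrazol-3-yl on an aromatic carbon.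

Compound 4, `CNC(=O)N1CCCc2ccc(NC(=O)c3ccc(-c4cc[nH]n4)cc3)cc21`, differs from compound 1 in this way: 1H-pyrazol-3-yl in place of phenyl on an aromatic carbon. Going by the values given here, no measured step covers this exchange of phenyl for 1H-pyrazol-3-yl; the step from compound 2 to compound 3 concerns a change on the pyrazole itself and does not bear on it. What compound 1 and compound 2 show together is that a phenyl compound and a 1H-pyrazol-3-yl compound on this core sit within the scatter of each other, although those two also differ in where the group sits. The expected outcome for compound 4 is therefore no step beyond the scatter, a number 4.3 percentage points higher from compound 1 to compound 4 (within the scatter). Compound 4 is estimated at 24%, within 8% to 40%.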

Compound 4, a percentage reported as inhibition, at one concentration (the size of the read-out at that concentration, not a potency): 92.5%
The estimate for compound 4 lay 68.5 percentage points below the measured number; the whole stated range lies below it.
By their numbers in this assay, from the lowest: compound 3; then compounds 1 and 2 (each within the scatter of the next); then compound 4.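

In this assay, 1H-pyrazol-3-yl in place of phenyl on an aromatic carbon, para to a large group, gives a number 72.8 percentage points higher from compound 1 to compound 4 (beyond the scatter), so the two rings are far from interchangeable at this position. The earlier compounds shown here could not show this, as none of their steps exchanged these two groups in one place. The entering ring differs from phenyl in ring size and hetero atoms and brings a hydrogen-bond donor and acceptor, but nothing measured here explains the step.

The compounds shown do not separate these differences, so it stays open which of them carries the step. On these data alone, what a 1-methyl-1H-pyrazol-3-yl group, which has a methyl on the ring nitrogen, or a pyridin-4-yl ring would give at this position also remains open.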